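A few compounds are considered here, and "the series" means these few. Any claim that something is new, unique, unknown or untested is made for them only; others in the source may bear on it.

Measured compounds in an assay on SK-BR-3 cells for inhibition of Aromatase (Homo sapiens); a higher number here means a weaker inhibitor, a lower number a stronger inhibitor:
- compound 1, `CN(c1ccc([N+](=O)[O-])cc1OC1CCCCC1)S(C)(=O)=O`, gives 470 nM
- compound 2, `CN(c1ccc([N+](=O)[O-])cc1OC1CCCC1)S(C)(=O)=O`, gives 440 nM

Compound 2 gives the lowest of the two numbers, but its nearest neighbour is compound 1, and the step of a 1.1-fold lower number from compound 1 to compound 2 (0.03 log units; within the scatter) is within the scatter, so the two compounds cannot be ordered on these data.

Compound 3, `COc1cc([N+](=O)[O-])ccc1N(C)S(C)(=O)=O`, has not yet been measured. It differs from compound 2 by methyl in place of cyclopentyl on an oxygen on an aromatic ring.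

Among the compounds with values here, only one measured step bears on this change: the exchange of cyclohexyl for cyclopentyl at the same oxygen, a 1.1-fold lower number from compound 1 to compound 2 (0.03 log units; within the scatter), which left the number unchanged beyond the scatter. That step shrinks the ring by one carbon; the step to compound 3 removes the ring entirely and leaves a single carbon, a far larger cut with no measured parallel. Given the indifference seen between compound 1 and compound 2, the author expects at most a modest rise in this assay for compound 3, a 1.8-fold higher number from compound 2 to compound 3 (0.26 log units; within the scatter), with wide uncertainty. The estimate for compound 3 is 800 nM, between 250 nM and 2500 nM.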

Compound 3, half-maximal inhibitory concentration: > 25000 nM
Compound 3 gave a limit, no number (the forecaster's own chance of this, stated with the estimate: 5%); middle value at least 31-fold (1.49 log units) away from the limit.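

In this assay, compound 3 gives > 25000 nM, which is a limit of the assay and not a number: the limit of > 25000 nM in this assay, at which 1 of the 3 values shown sits.

Cutting cyclopentyloxy to methoxy brings an at least 56-fold higher number from compound 2 to compound 3 (1.75 log units; beyond the scatter), and replacing cyclohexyl with methyl at the same oxygen brings an at least 53-fold higher number from compound 1 to compound 3 (1.72 log units; beyond the scatter). The substituent on this oxygen on an aromatic ring therefore matters far more than the exchange between compound 1 and compound 2 could show: the two rings could not be told apart, whereas methyl stands clearly apart from both.

The compounds shown do not settle whether the ring itself counts or only the size of the group, and an open chain such as isopropyl or butyl, or a small ring such as cyclopropyl, would separate those two readings. They also leave open how the number changes between methyl and cyclopentyl, and whether a group larger than cyclohexyl, such as benzyl, would still sit within the range of compound 1 and compound 2.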